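Methoxy for Carbamoyl: Expected Solubility of Compound 4

This account rests on a few compounds, and the source may have more. Where it says the series, first, only, none or still open, it means among the compounds named here.

Three ureas built on a shared core have been measured in a physicochemical assay for solubility, at pH 7.4; a lower number here means a less soluble compound, a higher number a more soluble compound. Compound 1 `Cc1cc(NC(=O)Nc2cccc(C(N)=O)c2)c2ccccc2n1` gives 100 nM. Compound 3 `Cc1cc(NC(=O)Nc2ccc(Cl)cc2Cl)c2ccccc2n1` gives 100 nM, level with compound 1 at the digits shown, and the two sit together at the bottom of the three numbers. Compound 2 `CSc1ccc(NC(=O)Nc2cc(C)nc3ccccc23)cc1` gives 1300 nM, a number far enough above compound 1 to lie beyond the scatter. No two of these measured compounds differ in only one place, so no single step can be read directly from them.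

Compound 4 `COc1cccc(NC(=O)Nc2cc(C)nc3ccccc23)c1` has not yet been measured in this assay. It differs from compound 1 in one place: methoxy in place of carbamoyl on an aromatic carbon. Compound 2, which also lacks the carbamoyl group, gives the highest number of the three, 1300 nM. On that slender basis a moderate step upward is expected, a 4.0-fold higher number from compound 1 to compound 4 (0.60 log units; beyond the scatter), though a smaller change could be swallowed by the scatter of this kind of measurement. Compound 4 is accordingly estimated at 400 nM, within a range from 130 nM to 1300 nM.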

Compound 4, solubility: 1200 nM
The estimate for compound 4 lay 3.0-fold (0.48 log units) below the measured number; the measured number falls inside the stated range.
By their numbers in this assay, from the lowest: compounds 1 and 3 (each within the scatter of the next); then compounds 4 and 2 (each within the scatter of the next).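

For the compounds shown here, the first single change that can be read in this assay is methoxy in place of carbamoyl on an aromatic carbon, meta to a large group, and it gives a 12-fold higher number from compound 1 to compound 4 (1.08 log units; beyond the scatter), so what sits at this position can move the number well beyond the scatter. The two groups differ in a countable way: carbamoyl has 3 heavy atoms, 1 hydrogen-bond donor and 1 hydrogen-bond acceptor, while methoxy has 2 heavy atoms, 0 hydrogen-bond donors and 1 hydrogen-bond acceptor. Nothing measured here shows which of these differences, if any, accounts for the step.

From the compounds shown here alone, this is one pair on one core, so it remains open whether the same swap would give a step of similar size at another position or on another core. Also open, going by these compounds, is how an amine, a carboxylic acid or a longer ether chain on this same aromatic carbon would compare with carbamoyl and methoxy, and such comparisons would help to show which feature of the group matters.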